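A few compounds are considered here, and "the series" means these few. Any claim that something is new, unique, unknown or untested is made for them only; others in the source may bear on it.

The study centres on a shared core, seen in its simplest form in compound 1 `C=C1C2=C(C(=O)N1OC)[C@H](O)[C@@](C)(O)[C@H](CCCCC)O2`, which in a functional assay on NCI-H929 cells (Homo sapiens) for cytotoxicity, read by MTT assay, with a stated time of 72 h (on this read-out higher numbers stand for weaker inhibition and lower numbers for stronger inhibition), gives 6500 nM. Compound 3 `C=C1C2=C(C(=O)N1OC)[C@@H](F)[C@@](C)(O)[C@H](CCCCC)O2` carries fluorine where compound 1 carries a hydroxyl. In this assay compound 3 gives 3900 nM. Compound 2 `C=C1C2=C(C(=O)N1OC)[C@H](OC(=O)CSc1nc3ccccc3s1)[C@@](C)(O)[C@H](CCCCC)O2`, an ester on that same position, gives 590 nM and stands with the lowest number of the three; its gap to compound 3 is the nearer one, and its gap to compound 1 the wider, and both lie beyond the usual scatter, so compound 2 is the most potent of the measured set.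

Compound 4 `C=C1C2=C(C(=O)N1OC)[C@H](OC(=O)CCl)[C@@](C)(O)[C@H](CCCCC)O2` has not yet been measured. It differs from compound 2 in one place: chloro in place of (1,3-benzothiazol-2-yl)sulfanyl on a saturated chain carbon bound to a carbonyl carbon. The ester linkage itself is kept, but a small single-atom substituent replaces a two-ring heteroaromatic thioether at the end of the acyl chain.

Compound 4 is expected to land closer to the unsubstituted compound 1, because compound 2 with its large ester reaches 590 nM while compound 1 sits at 6500 nM, and the change from compound 2 to compound 4 is estimated to give a step toward weaker inhibition of a 3.1-fold higher number from compound 2 to compound 4 (0.48 log units; beyond the scatter), beyond the scatter. Compound 4 is therefore estimated at 1800 nM, within a range from 600 nM to 5500 nM.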

Compound 4, half-maximal inhibitory concentration: 3300 nM
Compound 4: middle estimate off by 1.8-fold (0.26 log units), on the low side; the measured number falls inside the stated range.
By their numbers in this assay, from the lowest: compound 2; then compounds 4, 3 and 1 (each within the scatter of the next).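

In this assay, the step of a 5.6-fold higher number from compound 2 to compound 4 (0.75 log units; beyond the scatter) shows that keeping the ester linkage is not enough to hold the low number of compound 2: at this position, the number depends on what sits on the saturated chain carbon bound to the carbonyl carbon. The step of a 2.0-fold lower number from compound 1 to compound 4 (0.29 log units; within the scatter) adds that (chloromethyl)carbonyl on the oxygen cannot be told apart from the hydrogen of compound 1, so acylating this oxygen with that small group gives no separable change, and only the ester carrying (1,3-benzothiazol-2-yl)sulfanyl stands clear of compound 1. Nothing measured here explains why the two-ring thioether gives the lower number.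

The compounds shown leave open which part of (1,3-benzothiazol-2-yl)sulfanyl matters, the sulfur, the five-membered ring with its two hetero atoms or the six-membered carbon ring, and a phenylsulfanyl group or a plain hexylsulfanyl chain in its place would separate these parts. They also leave open whether an amine or a carboxylic acid at the end of the acyl chain would keep the number of compound 2 or fall back to that of compound 1.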